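The compounds below may be only part of what the source reports. "The series", "measured", "known", "first", "only" and "open" are said of these compounds alone.

Working notes on the series.

Compound 1 `Fc1ccccc1CSc1nnc(-c2ccncc2)n1-c1ccccc1` sits at the assay limit in a functional assay on HepG2 cells (Homo sapiens) for inhibition, read by MTT assay, with a stated time of 48 h (a higher number here means a weaker inhibitor, a lower number a stronger inhibitor), giving > 50000 nM, which is a limit and not a number. Compound 2 `Clc1ccc(CSc2nnc(-c3ccncc3)n2-c2ccccc2)cc1` gives 16900 nM in this assay. Compound 3 `O=C(CSc1nnc(-c2ccncc2)n1-c1ccccc1)N/N=C/c1ccc([N+](=O)[O-])cc1` gives 15900 nM in this assay; this is the lowest of the two numbers shown, but compound 2 is within the scatter of it, so no order between the two can be read. Compound 4 `O=C(CSc1nnc(-c2ccncc2)n1-c1ccccc1)N/N=C/c1cc(Br)cc(Br)c1O` is not yet measured in this assay. The change from compound 3 to compound 4 is 3,5-dibromo-2-hydroxyphenyl in place of 4-nitrophenyl on a carbon with a double bond to nitrogen. Going by the values given here, the only measured step, an at least 2.9-fold lower number from compound 1 to compound 2 (0.47 log units; beyond the scatter), alters the aryl group on a saturated chain carbon bound to a sulfur, a different place in the shared core, and rests on a limit (the limit of > 50000 nM in this assay, at which 1 of the 3 values shown sits); it does not bear directly on the present change. Among the compounds with values here, with no step at the hydrazone aryl to draw on, the expectation for compound 4 is a number close to that of compound 3, with a step of a 1.2-fold lower number from compound 3 to compound 4 (0.09 log units; within the scatter) expected to fall within the scatter. Compound 4 is therefore estimated at 13000 nM, between 4000 nM and 45000 nM.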

Compound 4, half-maximal inhibitory concentration: 7590 nM
For compound 4 the middle estimate is 1.7-fold (0.23 log units) above the measured one; the range from low to high includes it.
By their numbers in this assay, from the lowest: compound 4; then compounds 3 and 2 (each within the scatter of the next). At a limit, above all of these: compound 1.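

This is the first step shown at the aryl group on a carbon with a double bond to nitrogen. In this assay, it gives a 2.1-fold lower number from compound 3 to compound 4 (0.32 log units; beyond the scatter) and shows that the number responds, modestly, to the aryl group held at this place. The entering 3,5-dibromo-2-hydroxyphenyl differs from 4-nitrophenyl in several features at once, including its bromine atoms and its hydrogen-bond donor, and nothing shown gives a reason for the step.

The compounds shown leave open whether the bromine atoms, the hydroxyl group or their combination accounts for the step, with no singly brominated or simple hydroxyphenyl group to separate them. Going by these compounds, it also remains open how an amine or a carboxylic acid on this aryl ring would read in this assay.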